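Methyl in Place of Nitro on a Weakly Active Core

The compounds below may be only part of what the source reports. "The series", "measured", "known", "first", "only" and "open" are said of these compounds alone.

The shared core is seen in compound 1 `CC1=CSC(O)(c2ccc([N+](=O)[O-])cc2)c2noc(=O)n21` and in compound 2 `COC1(c2ccc(Br)cc2)SC=C(C)n2c1noc2=O`. In a functional assay on A2780 cells (Homo sapiens) for antiproliferative activity, read by MTT assay, with a stated time of 3 days (on this read-out lower numbers stand for stronger inhibition and higher numbers for weaker inhibition), compound 1 gives only a limit, > 100000 nM, and not a number. Compound 2 gives 148000 nM. Both readings sit at the weak end of the measurable range, and where compound 1 stands is known only from the limit itself: the limit of > 100000 nM in this assay, at which 1 of the 2 values shown sits.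

Compound 3 `CC1=CSC(O)(c2ccc(C)cc2)c2noc(=O)n21` differs from compound 1 by methyl in place of nitro on an aromatic carbon. Among the compounds with values here, no step between two measured compounds covers this change. With both measured compounds this weak, no shift beyond the usual scatter is expected in this assay in either direction. The expected step is a step that the limit leaves unreadable from compound 1 to compound 3. Compound 3 is accordingly expected to give about 150000 nM, with a likely range from 50000 nM to 500000 nM, and a real chance that again only a limit is reported.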

Compound 3, half-maximal inhibitory concentration: > 100000 nM
Compound 3: only a limit was reported; the forecaster's own chance of this, stated with the estimate: 55%; the middle value lies beyond the limit too.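

Within the data shown here, compound 1 and compound 3 each give only a limit and not a number, so no step between them can be read: the limit of > 100000 nM in this assay, at which 2 of the 3 values shown sit.

From the compounds shown here alone, how far either compound lies past that limit stays open, and so does whether methyl in place of nitro on an aromatic carbon changes activity at all.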